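Estimating compound 3 after an amine swap

This account rests on a few compounds, and the source may have more. Where it says the series, first, only, none or still open, it means among the compounds named here.

In an ADME assay on A549 cells (Homo sapiens) for cytotoxicity, read by resazurin assay, with a stated time of 48 h (a lower number here means that less compound is tolerated, a higher number that more compound is tolerated), compound 1 (`CC(C)Nc1ccc(NC(=O)c2cc(Cl)ccc2O)c(Cl)c1`) gives 11000 nM as its reading, and compound 2 (`O=C(Nc1ccc(N(CC2CC2)CC2CC2)cc1Cl)c1cc(Cl)ccc1O`) gives 12800 nM as its reading. For the measured compounds named here, these two numbers lie within the scatter of each other, so compound 2 stands level with the only other compound measured.

Compound 3 (`O=C(Nc1ccc(NCc2ccc(F)cc2)cc1Cl)c1cc(Cl)ccc1O`) has not yet been measured. The change that leads to it is (4-fluorobenzyl)amino in place of bis(cyclopropylmethyl)amino on an aromatic carbon and it puts (4-fluorobenzyl)amino in place of bis(cyclopropylmethyl)amino on an aromatic carbon, para to a large group.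

Going by the values given here, one measured step bears on this place: a 1.2-fold higher number from compound 1 to compound 2 (0.07 log units; within the scatter) with bis(cyclopropylmethyl)amino in place of isopropylamino. Among the compounds with values here, that step is small, yet it is the only guide, and neither measured compound has an aromatic ring in this group. Within the data shown here, the data therefore give no direct precedent for the incoming group, and a wide range is warranted.

No shift beyond the scatter is expected, and the estimated step is a 1.4-fold lower number from compound 2 to compound 3 (0.15 log units; within the scatter) in this assay as the working expectation. For compound 3 the estimated value is 9000 nM with an expected range from 3000 nM to 25000 nM in this measurement.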

Compound 3, half-maximal cytotoxic concentration: 54400 nM
For compound 3 the middle estimate is 6.0-fold (0.78 log units) below the measured one; the measured number lies above the stated range.
By their numbers in this assay, from the lowest: compounds 1 and 2 (each within the scatter of the next); then compound 3.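

In this assay, the group on this aromatic carbon proved able to move the number: a 4.3-fold higher number from compound 2 to compound 3 (0.63 log units; beyond the scatter), and a 4.9-fold higher number from compound 1 to compound 3 (0.69 log units; beyond the scatter), both beyond the scatter, whereas the exchange between the two groups without an aromatic ring gave only a 1.2-fold higher number from compound 1 to compound 2 (0.07 log units; within the scatter), within the scatter. The earlier pair might have suggested that this position was indifferent to what it carries, but that held only for isopropylamino and bis(cyclopropylmethyl)amino, and (4-fluorobenzyl)amino separates from both. Since the higher number appears against either of those two groups, it goes with the entering (4-fluorobenzyl)amino and not with one particular group that leaves, so more of compound 3 is tolerated by these cells than of either neighbour.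

With a single aromatic example, the compounds shown cannot tell whether the rise belongs to the six-membered aromatic ring, to the fluorine or to the whole group, and a plain benzylamino group or a cyclohexylmethylamino group would be needed to separate these. Nothing among the data shown accounts for the higher number.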